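Ortho substituent on the aryl piperazine: isopropyl for phenyl

The compounds below may be only part of what the source reports. "The series", "measured", "known", "first", "only" and "open" are said of these compounds alone.

Measured compounds in a functional assay on aorta for antagonist activity at Alpha-1D adrenergic receptor (Rattus norvegicus); a lower number here means tighter binding, a higher number weaker binding:
compound 1 `CN(C)C(=O)c1cccnc1NCCCN1CCN(c2ccccc2OC(F)(F)F)CC1` gives 100 nM
compound 2 `CN(C)C(=O)c1cccnc1NCCCN1CCN(c2ccccc2OCC2CC2)CC1` gives 10 nM
compound 3 `CN(C)C(=O)c1cccnc1NCCCN1CCN(c2ccccc2-c2ccccc2)CC1` gives 63.1 nM

Compound 3 stands second highest of the three numbers; its nearest neighbour is compound 1, and the difference a 1.6-fold lower number from compound 1 to compound 3 (0.20 log units; within the scatter) lies within the scatter. The widest gap is to compound 2, a 6.3-fold higher number from compound 2 to compound 3 (0.80 log units; beyond the scatter), and the related 10-fold lower number from compound 1 to compound 2 (1.00 log units; beyond the scatter) shows that exchanges at this position can move the number by a modest amount.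

Compound 4 `CC(C)c1ccccc1N1CCN(CCCNc2ncccc2C(=O)N(C)C)CC1` differs from compound 3 in one place: isopropyl in place of phenyl on an aromatic carbon. Among the compounds with values here, no measured step exchanges phenyl for isopropyl, so the expectation rests only on the two steps into and out of phenyl at this position, which range from within the scatter to modest. Within the data shown here, with no direct precedent the step of a 1.3-fold lower number from compound 3 to compound 4 (0.10 log units; within the scatter) is expected to stay within the scatter. For compound 4 the estimated number in this assay is 50 nM, with a range of 15 nM to 200 nM.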

Compound 4, dissociation constant: 63.1 nM
Beside the measured number, compound 4's estimate is 1.3-fold (0.10 log units) below it; measured number inside the range.
By their numbers in this assay, from the lowest: compound 2; then compounds 3, 4 and 1 (each within the scatter of the next).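

In this assay, isopropyl matches phenyl on this aromatic carbon, with no change at the digits printed from compound 3 to compound 4 (within the scatter), so a group with no ring and 3 heavy atoms reads the same here as a six-membered aromatic ring with 6 heavy atoms. Isopropyl also stays within the scatter of trifluoromethoxy, with a 1.6-fold lower number from compound 1 to compound 4 (0.20 log units; within the scatter), which puts three different groups at this place in one indistinguishable band. Cyclopropylmethoxy alone stands apart, with a 6.3-fold higher number from compound 2 to compound 4 (0.80 log units; beyond the scatter), and trifluoromethoxy shows that an oxygen on the aromatic carbon does not by itself bring this separation.

Nothing shown explains the separation of cyclopropylmethoxy or the match between isopropyl and phenyl. From the compounds shown here alone, whether a longer ether such as cyclobutylmethoxy, or a simple methoxy or an amine at this place, would join cyclopropylmethoxy or the other three groups remains open.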